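The compounds below may be only part of what the source reports. "The series", "measured", "known", "first", "only" and "open" are said of these compounds alone.

Measured in this study:
- compound 1 `O=C(NCc1ccc(OC(F)(F)F)c(Cl)c1)c1ccc(S(=O)(=O)Nc2ncns2)c(F)c1`: 13 nM
- compound 2 `O=C(NCc1ccc(OC(F)(F)F)c(Cl)c1)c1ccc(S(=O)(=O)Nc2ncc(F)cn2)c(F)c1`: 993 nM
- compound 3 `O=C(NCc1ccc(OC(F)(F)F)c(Cl)c1)c1ccc(S(=O)(=O)Nc2cccnn2)c(F)c1`: 1790 nM

In an assay on cells for inhibition of sodium channel protein type 3 subunit alpha (Homo sapiens), read by electrophysiology (on this read-out higher numbers stand for weaker inhibition and lower numbers for stronger inhibition), compound 1 stands lowest of the three numbers. Its nearest neighbour is compound 2, reached by a 76-fold higher number from compound 1 to compound 2 (1.88 log units; beyond the scatter); its furthest is compound 3, reached by a 140-fold higher number from compound 1 to compound 3 (2.14 log units; beyond the scatter). Between the other two the step is a 1.8-fold higher number from compound 2 to compound 3 (0.26 log units; within the scatter).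

Compound 4 `CN(Cc1ccc(OC(F)(F)F)c(Cl)c1)C(=O)c1ccc(S(=O)(=O)Nc2ncns2)c(F)c1` differs from compound 1 by methyl in place of hydrogen on an amide-type nitrogen. For the measured compounds named here, every measured step changes the group on the sulfonamide nitrogen; none alters the amide nitrogen, so no measured step bears directly on this change. Without such guidance, a modest move toward weaker inhibition is expected rather than none, giving a 3.1-fold higher number from compound 1 to compound 4 (0.49 log units; beyond the scatter). Compound 4 is therefore estimated at 40 nM, within a range of 8 nM to 300 nM.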

Compound 4, half-maximal inhibitory concentration in the sodium channel protein type 3 subunit alpha assay: 522 nM
Compound 4: the middle estimate sits 13-fold (1.12 log units) below what was measured; the measured number lies above the stated range.
By their numbers in the sodium channel protein type 3 subunit alpha assay, from the lowest: compound 1; then compounds 4, 2 and 3 (each within the scatter of the next, the first and the last beyond it).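

In the sodium channel protein type 3 subunit alpha assay, the amide hydrogen of compound 1 turns out to matter: methyl in its place gives a large step (a 40-fold higher number from compound 1 to compound 4 (1.60 log units; beyond the scatter)), so this amide-type nitrogen is as sensitive a position as the sulfonamide nitrogen, the only place changed before. In a physicochemical assay for lipophilicity (a higher number here means a more lipophilic compound, a lower number a more polar compound), compound 1 gives 2.1 and compound 4 gives 1.3. The same change thus gives a more polar compound despite the added carbon: the measured distribution coefficient of compound 1, 2.1, and of compound 4, 1.3, a number 0.80 log units lower (beyond the scatter)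

The compounds shown leave open whether the loss of the amide hydrogen or the presence of the methyl counts, and whether an ethyl or a hydroxyethyl group on this nitrogen would behave alike. From the compounds shown here alone, whether the step holds with 5-fluoropyrimidin-2-yl or pyridazin-3-yl on the sulfonamide nitrogen also stays open.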